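Bromo for Hydrogen Where Two Cytotoxicity Limits Stand

This account rests on a few compounds, and the source may have more. Where it says the series, first, only, none or still open, it means among the compounds named here.

Compound 1 `N#Cc1c(-c2ccccc2)c(C#N)c(=O)n(/N=C/c2cn(-c3ccccc3)nc2-c2ccccc2)c1N` is one of two compounds tested in an ADME assay on HeLa cells (Homo sapiens) for cytotoxicity, read by MTT assay; a lower number here means a stronger inhibitor, a higher number a weaker inhibitor. In this assay compound 1 gives only a limit, > 200 ug/mL. Compound 2 `N#Cc1c(-c2ccccc2[N+](=O)[O-])c(C#N)c(=O)n(/N=C/c2cn(-c3ccccc3)nc2-c2ccccc2)c1N` differs from compound 1 only by a nitro group. In this assay compound 2 likewise gives only a limit, > 200 ug/mL. The step that the two limits leave unreadable from compound 1 to compound 2 therefore has no readable size, because both values sit at the limit of > 200 ug/mL in this assay, at which 2 of the 2 values shown sit.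

Compound 3 `N#Cc1c(-c2ccccc2Br)c(C#N)c(=O)n(/N=C/c2cn(-c3ccccc3)nc2-c2ccccc2)c1N` differs from compound 1 by bromo in place of hydrogen on an aromatic carbon. Among the compounds with values here, the one measured step that also places a group on an aromatic carbon, a step that the two limits leave unreadable from compound 1 to compound 2, gives no size, so nothing among the measured compounds speaks for a step beyond the scatter in this assay, in either direction. Compound 3 is therefore expected to give about 200 ug/mL in this assay, within a range from 100 ug/mL to 400 ug/mL, and most likely again only as a limit. The expected step of a number no higher from compound 1 to compound 3 (the limit leaves the size open) is estimated to be of no readable size.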

Compound 3, half-maximal inhibitory concentration: > 200 ug/mL
Compound 3: no number, only a limit (the forecaster's own chance of this, stated with the estimate: 80%); the middle value lies on the limit itself.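

In this assay compound 3 gives > 200 ug/mL, which is a limit and not a number. Within the data shown here, no step among compound 1, compound 2 and compound 3 can be read, because all their values stand at one limit: the limit of > 200 ug/mL in this assay, at which 3 of the 3 values shown sit. The compounds shown leave open whether hydrogen, nitro and bromo on the aromatic carbon differ at all in this assay.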